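The source may report more compounds than this note shows. Statements on the series, on what has been measured and on what is new or still open speak of the compounds shown alone.

Measured compounds in a functional assay on BGC-823 cells (Homo sapiens) for cytotoxicity, read by MTT assay, with a stated time of 48 h; a higher number here means a weaker inhibitor, a lower number a stronger inhibitor:
compound 1 `CN(C)CCNc1ccnc2cc(OCc3ccc(F)cc3)ccc12` gives 890 nM
compound 2 `CN(C)CCNc1ccnc2cc(OCc3ccccc3)ccc12` gives 1250 nM

Compound 2 holds the higher of the two numbers, though the gap is a 1.4-fold higher number from compound 1 to compound 2 (0.15 log units; within the scatter) and so within the scatter; the two compounds cannot be placed in order.

Compound 3 `C=CCOc1ccc2c(NCCN(C)C)ccnc2c1` differs from compound 2 by vinyl in place of phenyl on a saturated chain carbon bound to an oxygen on an aromatic ring. For the measured compounds named here, the only measured step, from compound 1 to compound 2, concerns a fluoro on the phenyl that leaves here and was within the scatter, so it gives no direct read on removing the ring. Going by the values given here, no measured pair shows a benzyl replaced by an allyl. Accordingly the expectation rests on compound 2 alone, with wide uncertainty, and a small shift towards a higher number is assumed, a 2.0-fold higher number from compound 2 to compound 3 (0.30 log units; within the scatter), which may still fall within the scatter.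

Compound 3 is estimated at 2500 nM in this assay, in the range 1000 nM to 7000 nM.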

Compound 3, half-maximal inhibitory concentration: 1360 nM
The estimate for compound 3 lay 1.8-fold (0.26 log units) above the measured number; the measured number falls inside the stated range.
By their numbers in this assay, from the lowest: compounds 1, 2 and 3 (each within the scatter of the next).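

Earlier, only a fluoro on the phenyl had varied; now the ring itself is gone from the saturated chain carbon bound to an oxygen on an aromatic ring. In this assay, benzyloxy to allyloxy gives a 1.1-fold higher number from compound 2 to compound 3 (0.04 log units; within the scatter), and taking out the 4-fluorophenyl gives a 1.5-fold higher number from compound 1 to compound 3 (0.18 log units; within the scatter), so neither change can be read as a shift, and at this place the series shows no dependence on an aromatic ring. No measurement here accounts for this.

Going by these compounds, all three compounds carry a group without a charge or a hydrogen-bond donor or acceptor at this place, so it remains open whether an amine or a carboxylic acid in place of the vinyl would stay within the scatter. On these data alone, a longer chain in place of the allyl also remains untested in these data, as does any change to the rest of the shared core.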